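Varying the aryl group on a triazole hydroxamic acid series

This account rests on a few compounds, and the source may have more. Where it says the series, first, only, none or still open, it means among the compounds named here.

Measured compounds:
Compound 1, `Cc1ccccc1-n1nc(-c2ccccc2)nc1CNc1ccc(C(=O)NO)cc1`, gives 57.1%.
Compound 2, `O=C(NO)c1ccc(NCc2nc(-c3ccco3)nn2-c2ccccc2)cc1`, gives 59.9%.
Compound 3, `NC(=O)c1ccc(NCc2nc(-c3ccccc3)nn2-c2ccccc2)cc1`, gives -4.4%.

All three were tested in an assay on Sf9 cells for inhibition of protein deacetylase HDAC6 (Homo sapiens), read by fluorescence, with a stated time of 40 min, tested at 100 nM; a higher number here means more inhibition at the concentration tested (going by the name of the read-out), a lower number less inhibition. Compound 2 has the highest number of the three, but compound 1 lies only within the scatter of it, so no order between compound 1 and compound 2 can be read from these two values. Compound 3, which carries a carboxamide where the other two carry a hydroxamic acid, gives a number far lower than compound 2, a gap that lies well beyond the scatter.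

The unmeasured compound 4 is `CCc1ccc(-c2nc(CNc3ccc(C(=O)NO)cc3)n(-c3ccccc3)n2)cc1`. It differs from compound 2 in one place: 4-ethylphenyl in place of furan-2-yl on an aromatic carbon. Compound 1 already shows that a plain phenyl group at this carbon gives a number close to that of compound 2 with its furan-2-yl group, so a third aromatic group at the same carbon is expected to behave in much the same way. The step from compound 2 to compound 4 is expected to be a number 4.9 percentage points lower from compound 2 to compound 4 (within the scatter), that is, no change beyond the scatter. For compound 4 in this assay the estimate is 55%, with a likely range from 35% to 75%.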

Compound 4, a percentage reported as inhibition, at one concentration (the size of the read-out at that concentration, not a potency): 54.6%
The estimate for compound 4 lay 0.4 percentage points above the measured number, within the range that was stated.
By their numbers in this assay, from the lowest: compound 3; then compounds 4, 1 and 2 (each within the scatter of the next).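

In this assay, going by these compounds alone, putting 4-ethylphenyl in place of furan-2-yl on the aromatic carbon between two ring nitrogen atoms gives a number 5.3 percentage points lower from compound 2 to compound 4 (within the scatter), and this is the first step that changes this position alone. It shows that this carbon can carry a six-membered aromatic ring of carbon only, with 8 heavy atoms, in place of a five-membered aromatic ring with 5 heavy atoms, with no change beyond the scatter, even though the ring oxygen and its hydrogen-bond acceptor are gone. Nothing at hand gives a reason for this result.

Going by these compounds, it remains open whether the same holds for a group at this carbon without an aromatic ring, such as cyclohexyl, or for a phenyl ring that carries an amine or a carboxylic acid in place of the ethyl group. On these data alone, since the read-out reports inhibition at one concentration and is not a potency, it also remains open whether compound 2 and compound 4 would separate at other concentrations.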